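The source may report more compounds than this note shows. Statements on the series, on what has been measured and on what is new or still open speak of the compounds shown alone.

Measured compounds:
compound 1 `Cn1c(=O)c(=O)n(C2CCCC2)c2nc(N/N=C/c3ccc(F)c(Cl)c3)ncc21`, 9020 nM
compound 2 `COc1cccc(/C=N/Nc2ncc3c(n2)n(C2CCCC2)c(=O)c(=O)n3C)c1`, 45800 nM

Both numbers come from a functional assay on HCT-116 cells (Homo sapiens) for antiproliferative activity, read by MTT assay; on this read-out lower numbers stand for stronger inhibition and higher numbers for weaker inhibition. Compound 2 holds the highest number of the two; its nearest neighbour is compound 1, which sits at 9020 nM in this assay . For the measured compounds named here, the one measured step, a 5.1-fold higher number from compound 1 to compound 2 (0.71 log units; beyond the scatter), is therefore the whole of what is known about the aryl group on the carbon with a double bond to nitrogen.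

Compound 3 `Cn1c(=O)c(=O)n(C2CCCC2)c2nc(N/N=C/c3cc([N+](=O)[O-])ccc3Cl)ncc21` is not yet measured. It differs from compound 2 as follows: 2-chloro-5-nitrophenyl in place of 3-methoxyphenyl on a carbon with a double bond to nitrogen. Going by the values given here, the only step that bears on this is the one from compound 1 to compound 2, which exchanged a halogenated aryl for 3-methoxyphenyl and was modest but beyond the scatter. Compound 3 returns to a halogenated aryl, now with a nitro group as well, so a move back toward the number of compound 1 is expected, but the pattern rests on a single step and a different substitution, so wide bounds are kept.

Compound 3 is expected at 12000 nM in this assay , with a range from 4000 nM to 40000 nM. This would mean an expected step of a 3.8-fold lower number from compound 2 to compound 3 (0.58 log units; beyond the scatter).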

Compound 3, half-maximal inhibitory concentration: 5610 nM
Beside the measured number, compound 3's estimate is 2.1-fold (0.33 log units) above it, within the range that was stated.
By their numbers in this assay, from the lowest: compounds 3 and 1 (each within the scatter of the next); then compound 2.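

In this assay, the position on a carbon with a double bond to nitrogen tolerates more than one substitution pattern: a 1.6-fold lower number from compound 1 to compound 3 (0.21 log units; within the scatter), so 2-chloro-5-nitrophenyl and 3-chloro-4-fluorophenyl cannot be told apart here, even though they share only the chlorine. With an 8.2-fold lower number from compound 2 to compound 3 (0.91 log units; beyond the scatter) added to the earlier step, 3-methoxyphenyl in compound 2 now stands apart from both halogenated aryl groups, and compound 2 is the weakest of the three, whereas before it had only compound 1 for comparison. No supporting evidence bears on why the aryl groups rank this way.

From the compounds shown here alone, three aryl groups cannot separate the contribution of the chlorine from that of the nitro, fluoro or methoxy groups, so it remains open whether the methoxy group lowers activity or the chlorine raises it, and a plain phenyl or a 3-chlorophenyl would address this directly. Also open, going by these compounds, is how this position responds to a dimethylamino group, a carboxylic acid or a pyridine ring in place of the substituted phenyl, and whether any change here holds with other groups on the shared core.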